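Swapping a Phenylethenyl Arm for a Dimethoxyphenyl Ring

This account rests on a few compounds, and the source may have more. Where it says the series, first, only, none or still open, it means among the compounds named here.

Three compounds share one core and differ only in the group on a saturated ring carbon. Compound 1 `Cc1cc(O)c(C2=NN(c3ccc(S(N)(=O)=O)cc3)C(c3ccccc3O)C2)cc1Cl` carries a 2-hydroxyphenyl group there; in a functional assay on SF-268 cells (Homo sapiens) for antiproliferative activity, with a stated time of 48 h (on this read-out higher numbers stand for weaker inhibition of growth and lower numbers for stronger inhibition of growth), compound 1 gives 8060 nM. Compound 2 `Cc1cc(O)c(C2=NN(c3ccc(S(N)(=O)=O)cc3)C(c3ccccc3Cl)C2)cc1Cl` carries a 2-chlorophenyl group, and in this assay compound 2 gives 3720 nM. Compound 3 `Cc1cc(O)c(C2=NN(c3ccc(S(N)(=O)=O)cc3)C(/C=C/c3ccccc3)C2)cc1Cl` carries a 2-phenylethenyl group, and in this assay compound 3 gives 19500 nM, the highest number of the three, that is, the weakest growth inhibition. Going to it from the others: a 2.4-fold higher number from compound 1 to compound 3 (0.38 log units; beyond the scatter) and a 5.2-fold higher number from compound 2 to compound 3 (0.72 log units; beyond the scatter); between the two compounds bearing an aromatic ring, a 2.2-fold lower number from compound 1 to compound 2 (0.34 log units; beyond the scatter).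

Compound 4 `COc1ccc(C2CC(c3cc(Cl)c(C)cc3O)=NN2c2ccc(S(N)(=O)=O)cc2)cc1OC` is not yet measured. It differs from compound 3 in one place: 3,4-dimethoxyphenyl in place of 2-phenylethenyl on a saturated ring carbon. The two measured steps that bear on this change both ran the other way, from an aromatic ring on that carbon to the 2-phenylethenyl group, and both raised the number by a modest amount. Reversing that direction, a modest drop is expected, though no dimethoxyphenyl group has been measured here, so the size is uncertain. Compound 4 is therefore estimated at 5000 nM, within 2000 nM to 12000 nM, which would mean an expected step of a 3.9-fold lower number from compound 3 to compound 4 (0.59 log units; beyond the scatter).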

Compound 4, concentration for total growth inhibition: 100000 nM
Compound 4: the middle estimate sits 20-fold (1.30 log units) below what was measured; the measured number lies above the stated range.
By their numbers in this assay, from the lowest: compound 2; then compound 1; then compound 3; then compound 4.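

In this assay, an aromatic ring on this saturated ring carbon does not by itself give stronger growth inhibition than the 2-phenylethenyl group: the 3,4-dimethoxyphenyl group moves the number the opposite way from the 2-hydroxyphenyl and 2-chlorophenyl groups (with a 5.1-fold higher number from compound 3 to compound 4 (0.71 log units; beyond the scatter)). What the ring carries therefore counts for a great deal here, as the comparisons among aromatic rings show (a 12-fold higher number from compound 1 to compound 4 (1.09 log units; beyond the scatter); and a 27-fold higher number from compound 2 to compound 4 (1.43 log units; beyond the scatter)), and both of these steps are larger than any step among the first three compounds. Among these compounds, compound 4 now gives the weakest growth inhibition of the four, so the earlier steps, which spanned only the hydroxy and chloro rings and the 2-phenylethenyl group, gave no sign of how far the number can rise through a change at this one carbon.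

Still open, going by these compounds, is whether a plain phenyl group, a phenyl ring with a single methoxy group, or a phenyl ring bearing an amine or a carboxylic acid would fall nearer compound 2 or nearer compound 4. No measurement at hand gives a reason for the size of these steps.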